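Thiocarbamate diaryl ether series: acid dissociation notes

The compounds below may be only part of what the source reports. "The series", "measured", "known", "first", "only" and "open" are said of these compounds alone.

The series comprises compound 1 `Oc1ccc(OC(=S)Nc2ccc(Oc3ccc(C(F)(F)F)cc3)cc2)cc1`, compound 2 `O=[N+]([O-])c1ccc(Oc2ccc(NC(=S)Oc3ccc(O)cc3)cc2)cc1`, compound 3 `CC(=O)Nc1ccc(OC(=S)Nc2ccc(Oc3ccc([N+](=O)[O-])cc3)cc2)cc1` and the unmeasured compound 4 `CC(=O)Nc1ccc(OC(=S)Nc2ccc(Oc3ccc(C(F)(F)F)cc3)cc2)cc1`. In a physicochemical assay for acid dissociation, compound 1 gives 9.23. In this assay compound 2 gives 9.23, and compound 3 gives 9.04. The change between compound 2 and compound 1 is trifluoromethyl in place of nitro on an aromatic carbon, and it made no change at the digits printed from compound 2 to compound 1 (within the scatter). The cores of compound 3 and compound 2 differ by acetamido in place of hydroxy on an aromatic carbon, with a number 0.19 log units lower from compound 2 to compound 3 (within the scatter). Compound 4 carries trifluoromethyl in place of nitro on an aromatic carbon, which is the same change already seen between compound 2 and compound 1, with a matching place description, and that earlier change occurs twice among these four compounds.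

For compound 4 a step of no change at the digits printed from compound 3 to compound 4 (within the scatter) in this assay is expected, resting on compound 2 going to compound 1 with no change at the digits printed from compound 2 to compound 1 (within the scatter). The estimate for compound 4 in this assay is therefore 9.04, expected between 8.75 and 9.35.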

Compound 4, acid dissociation constant: 9.03
For compound 4 the middle estimate is 0.01 log units above the measured one; the range from low to high includes it.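

In this assay trifluoromethyl in place of nitro gives a number 0.01 log units lower from compound 3 to compound 4 (within the scatter) on the acetamido core and no change at the digits printed from compound 2 to compound 1 (within the scatter) on the hydroxy core, so the step stays within the scatter on both cores shown. The other new step, a number 0.20 log units lower from compound 1 to compound 4 (within the scatter) on the trifluoromethyl side, sits with a number 0.19 log units lower from compound 2 to compound 3 (within the scatter) on the nitro side, and since both also lie within the scatter, these four compounds give no sign that the two changes depend on each other, though two cores are a narrow basis and steps this small cannot show that the change carries over exactly. No measurement here bears on why these steps are so small.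

Open, going by these compounds, is whether the same holds when an amine or a carboxylic acid stands in place of the hydroxy or acetamido group. Also open, on these data alone, is whether a nitrile or a methoxy group in place of nitro would give a step of similar size in this assay on either core.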